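Three Limits on a Shared Core and a Fourth Benzyl Variant

The source may report more compounds than this note shows. Statements on the series, on what has been measured and on what is new or still open speak of the compounds shown alone.

Measured in a functional assay on the whole organism for antagonist activity, with Mus musculus as the target; a higher number here means that more compound is needed for the effect, a lower number that less compound is needed:
- compound 1 `COc1cc(N)c(Cl)cc1NC(=O)C1CCN(CC2CC2)CC1` gives > 10 mg/kg, a limit of the assay and not a number.
- compound 2 `COc1cc(N)c(Cl)cc1NC(=O)C1CCN(Cc2ccccc2Cl)CC1` gives > 4 mg/kg, likewise a limit.
- compound 3 `COc1cc(N)c(Cl)cc1NC(=O)C1CCN(Cc2ccc(C)c(C)c2)CC1` gives > 8 mg/kg, again a limit.

Where compound 3 stands is therefore known only as a limit, and the two other values shown beside it are limits as well: the limit of > 10 mg/kg in this assay, at which 1 of the 3 values shown sits, the limit of > 4 mg/kg in this assay, at which 1 of the 3 values shown sits, and (the limit of > 8 mg/kg in this assay, at which 1 of the 3 values shown sits). None of the three steps among the measured compounds can be read, since each pair sits behind two limits: a step that the two limits leave unreadable from compound 1 to compound 2, a step that the two limits leave unreadable from compound 1 to compound 3 and a step that the two limits leave unreadable from compound 2 to compound 3.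

Compound 4 `COc1cc(N)c(Cl)cc1NC(=O)C1CCN(Cc2ccccc2)CC1` differs from compound 3 in one place: phenyl in place of 3,4-dimethylphenyl on a saturated chain carbon bound to an amine nitrogen in a ring. Among the measured compounds shown here, no measured step bears readably on this change, so no size or direction can be expected from the numbers in hand; the only guide is that every compound on this core so far has stayed beyond the dose reached in this assay. Compound 4 is therefore expected to give about 10 mg/kg in this assay, with a range from 3 mg/kg to 30 mg/kg. This expectation means a step that the limit leaves unreadable from compound 3 to compound 4, which is as likely to be reported as another limit as to be a number.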

Compound 4, dose for half-maximal effect: 0.5 mg/kg
For compound 4 the middle estimate is 20-fold (1.30 log units) above the measured one; measured number below the stated range.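

Across the three changes in this assay, phenyl in place of 3,4-dimethylphenyl gives an at least 16-fold lower number from compound 3 to compound 4 (1.20 log units; beyond the scatter), hydrogen in place of chloro on an aromatic carbon gives an at least 8.0-fold lower number from compound 2 to compound 4 (0.90 log units; beyond the scatter), and phenyl in place of cyclopropyl gives an at least 20-fold lower number from compound 1 to compound 4 (1.30 log units; beyond the scatter). On the saturated chain carbon bound to an amine nitrogen in a ring, the outcome therefore depends on the group carried there: among these four compounds, only the unsubstituted phenyl of compound 4 gives a number, while the 2-chlorophenyl, 3,4-dimethylphenyl and cyclopropyl groups all stay at limits of the assay. The step from the dimethyl compound can be stated only as a minimum because compound 3 stands at a limit: the limit of > 8 mg/kg in this assay, at which 1 of the 4 values shown sits.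

The steps among compound 1, compound 2 and compound 3 still cannot be read, so these three groups cannot be ranked against one another. From the compounds shown here alone, it also remains open whether a single methyl or a fluoro on the phenyl ring would keep the low dose of compound 4, and whether a longer chain, such as phenylethyl in place of benzyl, would do so.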